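A few compounds are considered here, and "the series" means these few. Any claim that something is new, unique, unknown or untested is made for them only; others in the source may bear on it.

Compound 1 `COCCn1cc(C(=O)C(=O)Nc2ccc(OC)nc2)c2cc(Cl)ccc21`: in a functional assay on FaDu cells (Homo sapiens) for cytotoxicity, read by MTT assay, with a stated time of 72 h (on this read-out higher numbers stand for lower toxicity in this test and lower numbers for higher toxicity in this test), compound 1 gives > 10000 nM, which is a limit of the assay.
Compound 2 `COc1ccc(NC(=O)C(=O)c2cn(CC(C)(C)OC)c3ccccc23)cn1`: in this assay compound 2 gives > 10000 nM, also a limit.
Compound 3 `COc1ccc(NC(=O)C(=O)c2cn(C(C)C)c3c(OC)cccc23)cn1`: in this assay compound 3 gives > 10000 nM, again a limit.

Compound 2 therefore stands where every measured compound stands, at the limit of > 10000 nM in this assay, at which 3 of the 3 values shown sit; its value is a limit and not a number, so it can be neither ranked against the others nor set apart from them. Within the data shown here, no compound here differs from another in one place, so no measured step is available to guide expectations. Compound 4 `COCC(C)(C)n1cc(C(=O)C(=O)Nc2ccc(OC)nc2)c2ccccc21` is built from the same atoms as compound 2, joined differently: 1-(methoxymethyl)-1-methylethyl in place of 2-methoxy-2-methylpropyl on an aromatic nitrogen. With every measured value resting at the same limit, the step is expected to be a step that the limit leaves unreadable from compound 2 to compound 4, nothing beyond the usual scatter in either direction. Compound 4 is thus expected to give about 20000 nM in this assay, within a range of 10000 nM to 60000 nM, most probably reported again only as a limit.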

Compound 4, concentration lethal to 50% of the cells: 137 nM
For compound 4 the middle estimate is 150-fold (2.16 log units) above the measured one, and the stated range ends above it.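

On this aromatic nitrogen, the way the chain is joined matters: in this assay, 1-(methoxymethyl)-1-methylethyl in place of 2-methoxy-2-methylpropyl gives an at least 72-fold lower number from compound 2 to compound 4 (1.86 log units; beyond the scatter), and a lower number here stands for higher toxicity in this test. The two chains hold the same atoms and have the same counts of donors and acceptors, so those counts do not tell them apart, yet the change is large. Compound 4 is the only compound shown that gives a number, while the others rest at a limit: the limit of > 10000 nM in this assay, at which 3 of the 4 values shown sit.

From the compounds shown here alone, compound 2 carries only a limit, so the full size of this step stays unknown. Going by these compounds, what a tert-butyl group or a chain ending in an amine would do on this aromatic nitrogen also remains open.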